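Cyanoguanidine series: aryl substitution and minimum effective dose

The compounds below may be only part of what the source reports. "The series", "measured", "known", "first", "only" and "open" are said of these compounds alone.

Measured so far:
- compound 1, `CCC(C)(C)N/C(=N\C#N)Nc1ccccc1`: 50 mg/kg
- compound 2, `CCOc1ccccc1N/C(=N/C#N)NC(C)(C)CC`: 20 mg/kg

In a functional assay on the whole organism (blood, strain Wistar-Okamoto) with Rattus norvegicus as the target, with a stated time of 5 days (on this read-out lower numbers stand for an effect already at smaller amounts and higher numbers for an effect only at larger amounts of compound), compound 1 gives 50 mg/kg, the highest of the two numbers measured; its nearest neighbour is compound 2, which reaches 20 mg/kg. Among the measured compounds shown here, the only step measured is a 2.5-fold lower number from compound 1 to compound 2 (0.40 log units; beyond the scatter), a single substituent entering the aromatic ring.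

Compound 3, `CCC(C)(C)N/C(=N\C#N)Nc1ccc(N(C)C)cc1`, is not yet measured. It differs from compound 1 by dimethylamino in place of hydrogen on an aromatic carbon. The step from compound 1 to compound 2 bears on this only loosely: it shows that one group entering the ring lowered the number modestly, but the group and its place differ from those in compound 3, so no firm direction follows. A change of similar size or none beyond the scatter is expected, and the estimate for compound 3 is 30 mg/kg with a range of 12 mg/kg to 80 mg/kg, meaning an expected step of a 1.7-fold lower number from compound 1 to compound 3 (0.22 log units; within the scatter).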

Compound 3, minimum effective dose: > 50 mg/kg
Compound 3: no number, only a limit; the forecaster's own chance of this, stated with the estimate: 5%; middle value at least 1.6-fold (0.22 log units) from the limit.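

In this assay, dimethylamino on an aromatic carbon, para to a large group, gives a number no lower from compound 1 to compound 3 (the limit leaves the size open), whereas ethoxy in place of hydrogen gave a 2.5-fold lower number from compound 1 to compound 2 (0.40 log units; beyond the scatter). A group entering the ring of compound 1 therefore does not lower the number in every case: compound 2 follows that direction and compound 3 goes against it. Compound 3 is known only through a limit, so the size of its step stays open: the limit of > 50 mg/kg in this assay, at which 1 of the 3 values shown sits.

On these data alone, whether this outcome follows the group or its place remains open, and ethoxy on the carbon para to a large group would separate the two. Also open, as far as these compounds go, is how a primary amine or a carboxylic acid on that same carbon would read in this assay.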